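Dinitrophenyl for Dichlorophenyl on the Triazole Nitrogen

The source may hold more compounds than are shown below. What is called first, only, known or untested is meant among the compounds shown, and "the series" means these compounds.

Compound 1 `CCOc1ccc(-n2nncc2CN2C(=O)C3(C(C#N)=C(N)Oc4c(N)cc5nc6ccccc6nc5c43)c3ccccc32)cc1`: 26800 nM
Compound 2 `N#CC1=C(N)Oc2c(N)cc3nc4ccccc4nc3c2C12C(=O)N(Cc1cnnn1-c1ccc(Cl)cc1Cl)c1ccccc12`: > 50000 nM

In a functional assay on MCF7 cells (Homo sapiens) for antiproliferative activity, read by MTT assay, with a stated time of 48 h (a lower number here means a stronger inhibitor, a higher number a weaker inhibitor), compound 1 gives 26800 nM. For compound 2 the result is only a limit of the assay, > 50000 nM, so where it stands is known only as a floor (the limit of > 50000 nM in this assay, at which 1 of the 2 values shown sits). Among the compounds with values here, the one measured step that alters the aryl group on the triazole is an at least 1.8-fold higher number from compound 1 to compound 2 (0.27 log units; that floor lies within the scatter). Compound 3 `N#CC1=C(N)Oc2c(N)cc3nc4ccccc4nc3c2C12C(=O)N(Cc1cnnn1-c1ccc([N+](=O)[O-])cc1[N+](=O)[O-])c1ccccc12` differs from compound 2 by 2,4-dinitrophenyl in place of 2,4-dichlorophenyl on an aromatic nitrogen. Within the data shown here, no measured step exchanges these two groups, so no size or direction beyond the scatter can be predicted. Compound 3 is expected to remain near the floor, estimated at 50000 nM with a range of 20000 nM to 150000 nM. The expected step is a number no higher from compound 2 to compound 3 (the limit leaves the size open).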

Compound 3, half-maximal inhibitory concentration: 20900 nM
Compound 3: the middle estimate sits 2.4-fold (0.38 log units) above what was measured, and the stated range covers the measured number.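

In this assay, within the data shown here, 2,4-dinitrophenyl gives the first step on the triazole nitrogen that lies beyond the scatter (an at least 2.3-fold lower number from compound 2 to compound 3 (0.37 log units; beyond the scatter)). Compared with 4-ethoxyphenyl, the same group brings no separation (a 1.3-fold lower number from compound 1 to compound 3 (0.11 log units; within the scatter)), so two very different aryl groups read alike here. From the compounds shown here alone, the size of the first step stays open, since compound 2 is only a limit of the assay: the limit of > 50000 nM in this assay, at which 1 of the 3 values shown sits. The compounds shown leave open how a phenyl ring with a single nitro group, a single chlorine or an amine would read. Going by these compounds, whether any aryl group here can give a much lower number also remains open.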